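From compound 3 to compound 4: an oxo ring exchange

The source may report more compounds than this note shows. Statements on the series, on what has been measured and on what is new or still open speak of the compounds shown alone.

In an ADME assay on microsomes from liver (Mus musculus) for metabolic stability, read by LC-MS, using NADPH, with stated times of 15 min and 60 min, tested at 4.6 uM (a lower number here means that the compound disappears faster, a higher number that the compound lasts longer), compound 1 (`CC(C)N1CCC(c2ccc3c(c2)oc(=O)n3C(=O)NCCCCc2ccccc2)CC1`) gives 1 h, compound 2 (`CC(=O)N1CCC(c2ccc3c(c2)oc(=O)n3C(=O)NCCCCc2ccccc2)CC1`) gives 1 h and compound 3 (`CN1CCC(c2ccc3c(c2)oc(=O)n3C(=O)NCCCCc2ccccc2)CC1=O`) gives 0.583 h. The value of compound 3 lies within the scatter of the other two, so the three cannot be ranked.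

Compound 4 (`CN1CCN(c2ccc3c(c2)oc(=O)n3C(=O)NCCCCc2ccccc2)C(=O)C1`) has 4-methyl-2-oxopiperazin-1-yl in place of the 1-methyl-2-oxopiperidin-4-yl of compound 3, on an aromatic carbon of the shared core: 4-methyl-2-oxopiperazin-1-yl in place of 1-methyl-2-oxopiperidin-4-yl on an aromatic carbon. For the measured compounds named here, none of the measured compounds carries the entering ring, so this exchange has no direct precedent.

Three measured steps change the same aromatic substituent. They are no change at the digits printed from compound 1 to compound 2 (within the scatter), a 1.7-fold lower number from compound 1 to compound 3 (0.23 log units; within the scatter) and a 1.7-fold lower number from compound 2 to compound 3 (0.23 log units; within the scatter). All three stay within the scatter, so varying this group has not yet moved this assay measurably in these compounds. On that basis, no shift beyond the scatter is expected, and no direction is favoured with any confidence. The estimated step is a 1.2-fold higher number from compound 3 to compound 4 (0.08 log units; within the scatter), which is expected to remain within the scatter. For compound 4 the estimated value is 0.7 h, with an expected range from 0.35 h to 1.4 h.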

Compound 4, half-life: < 0.0834 h
Compound 4 was reported as a limit; the forecaster's own chance of this, stated with the estimate: 5%; at least 8.3-fold (0.92 log units) between middle value and limit.
By their numbers in this assay, from the lowest: compounds 3, 1 and 2 (each within the scatter of the next). At a limit, below all of these: compound 4.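

This aromatic carbon can move this assay beyond the scatter, which the earlier substituents did not show: the exchange gives an at least 6.9-fold lower number from compound 3 to compound 4 (0.84 log units; beyond the scatter), with 4-methyl-2-oxopiperazin-1-yl carrying 2 hetero atoms in its six-membered ring where 1-methyl-2-oxopiperidin-4-yl carries 1. The other two substituents, which lie within the scatter of each other and of compound 3, also separate clearly from the entering ring, with an at least 11-fold lower number from compound 2 to compound 4 (1.07 log units; beyond the scatter) and an at least 11-fold lower number from compound 1 to compound 4 (1.07 log units; beyond the scatter). Compound 4 is reported only as a limit: the limit of < 0.0834 h in this assay, at which 1 of the 4 values shown sits.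

The compounds shown leave open whether the drop follows the second ring nitrogen, the attachment of the ring to the aromatic carbon through nitrogen, or the carbonyl as placed in the 2-oxopiperazine. A 4-methylpiperazin-1-yl without the carbonyl, or a morpholin-4-yl, on the same aromatic carbon would help to separate these readings.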